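Compound 2 at the limit, and one change

This account rests on a few compounds, and the source may have more. Where it says the series, first, only, none or still open, it means among the compounds named here.

Values in a functional assay on Jurkat cells (Homo sapiens) for inhibition, read by CCK-8 assay, with a stated time of 48 h (a lower number here means a stronger inhibitor of growth, a higher number a weaker inhibitor of growth), so far:
Compound 1 (`Cc1ccccc1Nc1nc(Nc2ccccc2)ncc1Cl`): > 100000 nM as a limit
Compound 2 (`Cc1ccc(Nc2ncc(Cl)c(Nc3ccccc3C)n2)cc1`): > 100000 nM as a limit
Compound 3 (`Cc1ccccc1Nc1nc(Nc2ccc(N3CCN(C)CC3)cc2)ncc1Cl`): not yet measured

Compound 2 stands at the limit of > 100000 nM in this assay, at which 2 of the 2 values shown sit, and has no number of its own. The change to compound 3 is 4-methylpiperazin-1-yl in place of methyl on an aromatic carbon with 4-methylpiperazin-1-yl in place of methyl on an aromatic carbon. Going by the values given here, the only measured step that bears on it is a step that the two limits leave unreadable from compound 1 to compound 2 and it offers no size to carry over. The expectation therefore rests on the structural change alone, in which a larger group replaces the methyl. In this assay any readable step is expected toward stronger growth inhibition because compound 2 gives the limit > 100000 nM and no weaker reading can be told. A result again at the limit remains possible. The estimated step is an at least 12-fold lower number from compound 2 to compound 3 (1.09 log units; beyond the scatter) and its size is highly uncertain. For compound 3 the expected value is 8000 nM with an estimated range from 1500 nM to 50000 nM in this assay.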

Compound 3, concentration for 50% growth inhibition: 13700 nM
Beside the measured number, compound 3's estimate is 1.7-fold (0.23 log units) below it; the range from low to high includes it.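

In this assay, the aromatic carbon that carries this change is the first place among these compounds where a substitution gives a readable result: 4-methylpiperazin-1-yl in place of methyl gives an at least 7.2-fold lower number from compound 2 to compound 3 (0.86 log units; beyond the scatter). The same group in place of hydrogen gives an at least 7.2-fold lower number from compound 1 to compound 3 (0.86 log units; beyond the scatter), so the stronger growth inhibition appears from either starting compound, whereas the step from hydrogen to methyl at this carbon cannot be read. Compound 1 and compound 2 both rest on a limit of the assay and not on a number, so each of these steps bounds a size without fixing it: the limit of > 100000 nM in this assay, at which 2 of the 3 values shown sit.

What the compounds shown leave open is which part of the entering group goes with the change, whether its six-membered ring, its two nitrogens or the methyl it carries. A morpholine, an unsubstituted piperazine or an open-chain dimethylamino group on the same carbon would separate these parts, and the same 4-methylpiperazin-1-yl group on another carbon of that ring would test whether the place matters as well as the group.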